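Ester to Primary Amide on a Shared Thiazole Core

The compounds below may be only part of what the source reports. "The series", "measured", "known", "first", "only" and "open" are said of these compounds alone.

Measured compounds:
- compound 1 `CCOC(=O)c1sc(-c2cccc(NC(=O)c3ccccc3F)c2)nc1Nc1ccc(N2CCN(C)CC2)cc1`: 2000 nM
- compound 2 `CCOC(=O)c1sc(-c2cccc(NC(=O)c3ccc(C#N)cc3)c2)nc1Nc1ccc(N2CCN(C)CC2)cc1`: 4280 nM
- compound 3 `CCOC(=O)c1sc(-c2cccc(NC(=O)c3ccco3)c2)nc1Nc1ccc(N2CCN(C)CC2)cc1`: "not determined" (no result reported)

In a functional assay on Ramos cells (Homo sapiens) for antiproliferative activity, read by CCK-8 assay, with a stated time of 72 h (on this read-out lower numbers stand for stronger inhibition and higher numbers for weaker inhibition), compound 1 gives 2000 nM, the lowest of the two numbers available. Its nearest neighbour is compound 2, which in this assay gives 4280 nM; the change a 2.1-fold higher number from compound 1 to compound 2 (0.33 log units; beyond the scatter) is modest and lies beyond the scatter. Compound 3 in this assay gives "not determined" (no result reported), so no number is available for it.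

Compound 4 `CN1CCN(c2ccc(Nc3nc(-c4cccc(NC(=O)c5ccccc5F)c4)sc3C(N)=O)cc2)CC1` differs from compound 1 in one place: amino in place of ethoxy on a carbonyl carbon. Among the measured compounds shown here, the only measured step, from compound 1 to compound 2, concerns the group on the amide carbonyl at the other end of the molecule, so no measured step bears directly on the ethoxycarbonyl-to-carbamoyl change. With nothing to point in either direction, the expectation is a step of no clear size beyond the scatter, and compound 4 is estimated at no change at the digits printed from compound 1 to compound 4 (within the scatter) in this assay. Compound 4 is therefore expected to give about 2000 nM, with a range from 600 nM to 7000 nM.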

Compound 4, half-maximal inhibitory concentration: 1360 nM
Estimate against measurement, compound 4: 1.5-fold (0.17 log units) above, within the range that was stated.
By their numbers in this assay, from the lowest: compounds 4 and 1 (each within the scatter of the next); then compound 2.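

In this assay the ethoxycarbonyl of compound 1 can become a carbamoyl with only a 1.5-fold lower number from compound 1 to compound 4 (0.17 log units; within the scatter) as the result. For this pair, then, the ethoxy on the carbonyl carbon is not needed to keep activity at this level, and amino can stand in its place even though it is a smaller group. Nothing measured here explains this result.

Going by these compounds, whether the same exchange is tolerated when the other end of the molecule carries the 4-cyanophenyl of compound 2 remains open, since one pair cannot show a general rule. Also open, on these data alone, is how a carboxylic acid, a methylamide or an ester with a longer chain on the same carbonyl carbon would read in this assay with the rest of the molecule unchanged.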